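Swapping the Amide Chain for a Methylpiperidine Ring

A few compounds are considered here, and "the series" means these few. Any claim that something is new, unique, unknown or untested is made for them only; others in the source may bear on it.

Two compounds have been measured in an assay on isolated protein for inhibition of Discoidin domain-containing receptor 2 (Homo sapiens), read by ELISA, with a stated time of 60 min; a higher number here means a weaker inhibitor, a lower number a stronger inhibitor:
compound 1 `Cc1ccc(C(=O)Nc2cccc(C(F)(F)F)c2)cc1-c1ccc2c(-c3cnn(CC(C)O)c3)n[nH]c2c1`, 3.7 nM
compound 2 `Cc1ccc(C(=O)Nc2cccc(C(F)(F)F)c2)cc1-c1ccc2c(-c3cnn(CC(=O)N(C)C)c3)n[nH]c2c1`, 2.7 nM

Going by the values given here, compound 2 holds the lowest of the two numbers, but its only neighbour, compound 1, sits within the scatter: the step of a 1.4-fold lower number from compound 1 to compound 2 (0.14 log units; within the scatter) shows that exchanging the hydroxyethyl for the dimethylcarbamoyl chain changed nothing that can be trusted.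

Compound 3 `Cc1ccc(C(=O)Nc2cccc(C(F)(F)F)c2)cc1-c1ccc2c(-c3cnn(C4CCN(C)CC4)c3)n[nH]c2c1` is the next variation on the same core. The change from compound 2 is 1-methylpiperidin-4-yl in place of (dimethylcarbamoyl)methyl on an aromatic nitrogen. Among the compounds with values here, no measured step covers anything like this exchange; the one step in hand, from compound 1 to compound 2, touched the same position but swapped two open chains and stayed within the scatter. There is therefore no ground for predicting a move in this assay in either direction, and compound 3 is expected to give about 3 nM, a step of a 1.1-fold higher number from compound 2 to compound 3 (0.05 log units; within the scatter), within a range of 1 nM to 9 nM.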

Compound 3, half-maximal inhibitory concentration: 3.8 nM
The estimate for compound 3 lay 1.3-fold (0.10 log units) below the measured number; the measured number falls inside the stated range.
By their numbers in this assay, from the lowest: compounds 2, 1 and 3 (each within the scatter of the next).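

In this assay, a ring on this aromatic nitrogen reads no differently from either open chain: the 1-methylpiperidin-4-yl group gives a 1.4-fold higher number from compound 2 to compound 3 (0.15 log units; within the scatter) and also a 1.0-fold higher number from compound 1 to compound 3 (0.01 log units; within the scatter), both small enough to be ordinary scatter. The earlier pair compared only two open chains, whereas these steps extend the same flat reading to one six-membered non-aromatic ring with 1 hetero atom, so across these three compounds the position accepts all three groups without a readable difference. No separate measurement offers any explanation for this result.

The compounds shown leave open whether a carboxylic acid, a primary amine or a much longer chain on this nitrogen would read the same. From the compounds shown here alone, a bare hydrogen there, with no group at all, is equally open.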